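The source may report more compounds than this note shows. Statements on the series, on what has been measured and on what is new or still open speak of the compounds shown alone.

Three compounds share one core and differ only in the aromatic group that sits on a saturated chain carbon bound to an amine nitrogen in a ring. Compound 1 `CCc1nc(C)c(CN2CCN(c3cccc4[nH]c(-c5ccc(C(C)(C)C)cc5)nc34)CC2)o1` gives 37 nM in an assay on isolated protein for displacement of a labelled ligand from Gonadotropin-releasing hormone receptor (Homo sapiens); on this read-out higher numbers stand for weaker inhibition and lower numbers for stronger inhibition. Compound 2 `Cc1nc(CN2CCN(c3cccc4[nH]c(-c5ccc(C(C)(C)C)cc5)nc34)CC2)c(C)s1` gives 21 nM in this assay, and compound 3 `CCCn1cnc(CN2CCN(c3cccc4[nH]c(-c5ccc(C(C)(C)C)cc5)nc34)CC2)c1C` gives 12 nM in this assay. Compound 3 thus has the lowest of the three numbers: the step of a 3.1-fold lower number from compound 1 to compound 3 (0.49 log units; beyond the scatter) lies beyond the scatter, whereas a 1.8-fold lower number from compound 2 to compound 3 (0.24 log units; within the scatter) and a 1.8-fold lower number from compound 1 to compound 2 (0.25 log units; within the scatter) both lie within it. Compound 4 `Cc1nc(CN2CCN(c3cccc4[nH]c(-c5ccc(C(C)(C)C)cc5)nc34)CC2)cn1C` carries the change (1,2-dimethyl-1H-imidazol-4-yl in place of 5-methyl-1-propyl-1H-imidazol-4-yl on a saturated chain carbon bound to an amine nitrogen in a ring). All three measured steps bear on this change, since each swaps one five-membered aromatic ring with 2 hetero atoms for another at the same place, and none of them moved the number by more than a modest amount. The change to compound 4 is therefore expected to give at most a small step in this assay, if anything toward a slightly higher number, as expressed by a 1.7-fold higher number from compound 3 to compound 4 (0.22 log units; within the scatter). Compound 4 is estimated at 20 nM, with an expected range from 7 nM to 60 nM.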

Compound 4, half-maximal inhibitory concentration: 10 nM
Beside the measured number, compound 4's estimate is 2.0-fold (0.30 log units) above it; measured number inside the range.
By their numbers in this assay, from the lowest: compounds 4, 3, 2 and 1 (each within the scatter of the next, the first and the last beyond it).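

Swapping 5-methyl-1-propyl-1H-imidazol-4-yl for 1,2-dimethyl-1H-imidazol-4-yl, with 7 heavy atoms in place of 9, leaves the number in this assay within the scatter (a 1.2-fold lower number from compound 3 to compound 4 (0.08 log units; within the scatter)), so the propyl-bearing group is not required at this place to keep the number at that level. Compound 4 also separates from the thiazole compound by a modest step (a 2.1-fold lower number from compound 2 to compound 4 (0.32 log units; beyond the scatter)), a separation that compound 3 did not show. The gap to the oxazole compound is likewise modest (a 3.7-fold lower number from compound 1 to compound 4 (0.57 log units; beyond the scatter)), so both imidazole compounds lie beyond the scatter from compound 1.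

The compounds shown leave open whether the plain 1H-imidazol-4-yl group, without methyl groups, or a pyridine ring would hold the number at this place. Nothing measured here accounts for these steps.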